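The compounds below may be only part of what the source reports. "The series", "measured", "known", "first", "only" and "open" are said of these compounds alone.

Three compounds share one core and differ only in the group carried on one aromatic carbon of that shared core. Compound 1 `CC(=O)N[C@@H]1CCC[C@H](C(=O)Nc2cc(-c3cnn(C)c3C)c(Cl)cn2)C1` gives 10 uL/min in an ADME assay on cells (Hepatocyte, Rattus norvegicus) for metabolic stability, using equilibrium dialysis; a higher number here means faster removal of the compound, a lower number slower removal. Compound 2 `CC(=O)N[C@@H]1CCC[C@H](C(=O)Nc2cc(-c3cnc4n3CCC4)c(Cl)cn2)C1` gives 19 uL/min in this assay, and compound 3 `CC(=O)N[C@@H]1CCC[C@H](C(=O)Nc2cc(-c3cnn4c3COCC4)c(Cl)cn2)C1` gives 18 uL/min. Compound 3 thus stands second highest of the three numbers; its nearest neighbour is compound 2 and its furthest is compound 1, and both gaps are within the scatter. Compound 4 `CC(=O)N[C@@H]1CCC[C@H](C(=O)Nc2cc(-c3cnn4c3OCCC4)c(Cl)cn2)C1` has the same atoms as compound 3, joined differently: a group of 9 heavy atoms (6 carbon, 2 nitrogen, 1 oxygen; one five-membered aromatic ring with 2 hetero atoms, one six-membered non-aromatic ring with 2 hetero atoms) in place of a group of 9 heavy atoms (6 carbon, 2 nitrogen, 1 oxygen; one five-membered aromatic ring with 2 hetero atoms, one six-membered non-aromatic ring with 2 hetero atoms), on an aromatic carbon. Every measured step at this position was small: a 1.9-fold higher number from compound 1 to compound 2 (0.28 log units; within the scatter), a 1.8-fold higher number from compound 1 to compound 3 (0.26 log units; within the scatter) and a 1.1-fold lower number from compound 2 to compound 3 (0.02 log units; within the scatter) all stayed within the scatter. Within the data shown here, no measured step compares two arrangements of the same atoms in this group, so the only guide is that exchanges of the group at this position have so far not moved the number beyond the scatter. No step beyond the scatter is therefore expected, no change at the digits printed from compound 3 to compound 4 (within the scatter). Compound 4 is estimated at 18 uL/min in this assay, with a range from 9 uL/min to 36 uL/min.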

Compound 4, intrinsic clearance in a liver preparation (reported as CLH), per the amount of preparation that the assay uses: 34 uL/min
Compound 4: middle estimate off by 1.9-fold (0.28 log units), on the low side; the range from low to high includes it.
By their numbers in this assay, from the lowest: compounds 1, 3, 2 and 4 (each within the scatter of the next, the first and the last beyond it).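

Among these compounds, the first comparison of two arrangements of the same atoms in this group comes from this assay, where a 1.9-fold higher number from compound 3 to compound 4 (0.28 log units; within the scatter) stays within the scatter, so this exchange of the oxygen's place in the six-membered non-aromatic ring cannot be told apart from repeat measurement, and the same holds for a 1.8-fold higher number from compound 2 to compound 4 (0.25 log units; within the scatter). Among the compounds shown here, what is new is a 3.4-fold higher number from compound 1 to compound 4 (0.53 log units; beyond the scatter), the first step on this aromatic carbon to pass beyond the scatter, so exchanges of the group here can separate two compounds, if only modestly and only between the two ends of the series, since each neighbouring pair remains within the scatter. No other information bears on these differences, and nothing shown explains them.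

The compounds leave open whether a nitrogen in place of the ring oxygen, as a secondary amine, would stay within the same span, and whether an open methoxyethyl chain in place of the fused ring would do so. They also leave open whether a carboxylic acid on the group would carry the number beyond the scatter from compound 3.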